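The source may report more compounds than this note shows. Statements on the series, on what has been measured and on what is new or still open speak of the compounds shown alone.

Measured so far:

Compound 1, `Cc1ccc(-c2csc(NC(=O)COc3ccccc3C(C)C)n2)cc1`, gives 42900 nM in a functional assay on Ehrlich cells (Mus musculus) for cytotoxicity, read by MTT assay, with a stated time of 48 h; on this read-out higher numbers stand for weaker inhibition and lower numbers for stronger inhibition.
Compound 2, `CC(C)c1ccccc1OCC(=O)Nc1nc(-c2ccc(Br)cc2)cs1`, gives 50900 nM in this assay.
Compound 3, `Cc1ccc(OCC(=O)Nc2nc(-c3ccc(C)cc3)cs2)cc1`, gives 45700 nM in this assay.

Compound 1 and compound 2 differ in one place: bromo in place of methyl on an aromatic carbon. This change gave a 1.2-fold higher number from compound 1 to compound 2 (0.07 log units; within the scatter), so the two values are indistinguishable within the usual scatter. Compound 3 and compound 1 differ in more than one place; the difference between the two cores is not broken down here. The three measured values all lie within the scatter of one another, so no order among them can be stated.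

Compound 4, `Cc1ccc(OCC(=O)Nc2nc(-c3ccc(Br)cc3)cs2)cc1`, is not yet measured. It differs from compound 3 in one place: bromo in place of methyl on an aromatic carbon. The place is described in the same words as for the change from compound 1 to compound 2, so this is the same change made on the core of compound 3. Among the measured compounds shown here, the step expected from compound 3 to compound 4 in this assay is a 1.2-fold higher number from compound 3 to compound 4 (0.07 log units; within the scatter), resting on the single precedent a 1.2-fold higher number from compound 1 to compound 2 (0.07 log units; within the scatter), which was within the scatter. On that basis compound 4 is estimated at 54000 nM, with a plausible range from 30000 nM to 95000 nM.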

Compound 4, half-maximal inhibitory concentration: 55800 nM
Beside the measured number, compound 4's estimate is 1.0-fold (0.01 log units) below it; low and high end bracket the measured number.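

In this assay, the change from 4-methylphenyl to 4-bromophenyl on the core of compound 3 gives a 1.2-fold higher number from compound 3 to compound 4 (0.09 log units; within the scatter), and this step can be set beside the earlier one on the core of compound 1: the same change on two cores in this assay, a 1.2-fold higher number (0.07 log units; within the scatter) from compound 1 to compound 2 and a 1.2-fold higher number (0.09 log units; within the scatter) from compound 3 to compound 4, 1.0-fold (0.01 log units) apart, within the scatter of two such steps. On these two cores the change therefore carries over without a readable difference, and the step seen on one core would have served as a fair guide to the step on the other. This does not show that a step of real size would transfer, as neither step lies beyond the scatter, and two cores give no basis for a rule covering the rest of the series.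

From the compounds shown here alone, it remains open whether another kind of group at this place, such as an amine or a carboxylic acid, would give a step beyond the scatter on either core, and whether that step would then hold from one core to the other. Also open, going by these compounds, is what a longer chain in place of the methyl would do in this assay.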